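From Pyrrolidinyl to Dimethylamino: Expected Cell Toxicity

The source may report more compounds than this note shows. Statements on the series, on what has been measured and on what is new or still open speak of the compounds shown alone.

Compound 1 `Cc1ccc(C(=O)Nc2cc3nc(C4CCCCC4)[nH]c3cc2N2CCCC2)cc1` has been tested in an ADME assay on Vero cells (Chlorocebus sabaeus) for cytotoxicity, read by resazurin assay, with a stated time of 3 days; on this read-out lower numbers stand for stronger inhibition and higher numbers for weaker inhibition. In this assay compound 1 gives only a limit, > 100 ug/mL. Compound 2 `O=C(Nc1cc2nc(C3CCCCC3)[nH]c2cc1N1CCCC1)c1ccccc1` likewise gives a limit in this assay, > 100 ug/mL. Compound 3 `O=C(Nc1cc2nc(C3CCCCC3)[nH]c2cc1N1CCCC1)OCC(F)(F)F` also gives a limit in this assay, > 100 ug/mL. The steps a step that the two limits leave unreadable from compound 1 to compound 2, a step that the two limits leave unreadable from compound 1 to compound 3 and a step that the two limits leave unreadable from compound 2 to compound 3 therefore cannot be read, because of the limit of > 100 ug/mL in this assay, at which 3 of the 3 values shown sit. Compound 4 `Cc1ccc(C(=O)Nc2cc3nc(C4CCCCC4)[nH]c3cc2N(C)C)cc1` differs from compound 1 by dimethylamino in place of pyrrolidin-1-yl on an aromatic carbon. Among the compounds with values here, no measured step touches this position, and the changes at the carbonyl carbon left nothing readable. Compound 4 is thus expected to show a step of a number no higher from compound 1 to compound 4 (the limit leaves the size open) in this assay. The estimate for compound 4 is 100 ug/mL, with a range from 50 ug/mL to 200 ug/mL, and most probably again only a limit.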

Compound 4, half-maximal inhibitory concentration: > 100 ug/mL
Compound 4 was reported as a limit (the forecaster's own chance of this, stated with the estimate: 80%); the middle value sits exactly at the limit.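

No new step can be read between compound 1 and compound 4, because the result is again only a limit: the limit of > 100 ug/mL in this assay, at which 4 of the 4 values shown sit.

The compounds shown leave open whether dimethylamino in place of pyrrolidin-1-yl, or any change on the carbonyl carbon, shifts the number in this assay at all.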